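The source may report more compounds than this note shows. Statements on the series, on what has been measured and on what is new or still open speak of the compounds shown alone.

Measured compounds:
- Compound 1, `CCOC(=O)C1=Cc2ccccc2OC1(OCc1cn(CC(=O)Nc2cccc(Cl)c2)nn1)C(F)(F)F`, in a functional assay on A549 cells (Homo sapiens) for inhibition, read by MTT assay, with a stated time of 24 h (a higher number here means a weaker inhibitor, a lower number a stronger inhibitor), gives 12800 nM.
- Compound 2, `CCCCCCCCn1cc(COC2(C(F)(F)F)Oc3ccccc3C=C2C(=O)OCC)nn1`, reaches only a limit of this assay, > 150000 nM.
- Compound 3, `CCOC(=O)C1=Cc2ccccc2OC1(OCc1cn(CC(=O)Nc2ccc(OC)cc2)nn1)C(F)(F)F`, in this assay gives 29400 nM.

Among the measured compounds shown here, of the two numbers known, compound 3 sits highest; its nearest neighbour is compound 1, and the step is a 2.3-fold higher number from compound 1 to compound 3 (0.36 log units; beyond the scatter). Compound 4, `CCOC(=O)C1=Cc2ccccc2OC1(OCc1cn(-c2ccccc2)nn1)C(F)(F)F`, has not been measured. It differs from compound 3 in one place: phenyl in place of ((4-methoxyphenyl)carbamoyl)methyl on an aromatic nitrogen. The amide-bearing arm is thus gone entirely, and only a bare aromatic ring remains on the triazole nitrogen.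

Two measured steps speak to this. Removing the (3-chlorophenyl)carbamoyl group for a plain heptyl chain gave an at least 11-fold higher number from compound 1 to compound 2 (1.06 log units; beyond the scatter), and restoring an amide arm gave an at least 5.1-fold lower number from compound 2 to compound 3 (0.70 log units; beyond the scatter), so the amide arm appears to matter greatly, with only these three compounds as support. Compound 4 also lacks any such arm, so a weakening step is expected: a 2.4-fold higher number from compound 3 to compound 4 (0.38 log units; beyond the scatter). The value of compound 4 is therefore estimated at 70000 nM, within 25000 nM to 200000 nM, with a real chance that the assay reports only (the limit of > 150000 nM in this assay, at which 1 of the 3 values shown sits).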

Compound 4, half-maximal inhibitory concentration: > 150000 nM
Compound 4 was reported as a limit; the forecaster's own chance of this, stated with the estimate: 35%; at least 2.1-fold (0.33 log units) between middle value and limit.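

Compound 4 gives only a limit and not a number, and compound 2 gives the same limit: the limit of > 150000 nM in this assay, at which 2 of the 4 values shown sit.

In this assay, the loss of the whole amide arm from the aromatic nitrogen, with phenyl in its place, brings an at least 5.1-fold higher number from compound 3 to compound 4 (0.70 log units; beyond the scatter) and an at least 11-fold higher number from compound 1 to compound 4 (1.06 log units; beyond the scatter). So an aromatic ring on that nitrogen does not stand in for the arm: among these four compounds, the two carrying a carbamoyl arm, compound 1 and compound 3, give numbers, while compound 2 and compound 4, without one, do not, and the step between those two cannot be read.

From the compounds shown here alone, it remains open whether the amide itself or the aromatic ring at its far end matters more. A benzyl group on that nitrogen, or an amide arm ending in a methyl group, would help separate the two.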